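Swapping the aryl group on a thiazole acetic acid core

The source may hold more compounds than are shown below. What is called first, only, known or untested is meant among the compounds shown, and "the series" means these compounds.

Measured compounds:
compound 1, `N#Cc1cc(-c2nc(C(c3ccc(F)cc3)c3ccc(F)cc3)sc2CC(=O)O)ccc1F`, 57 nM
compound 2, `O=C(O)Cc1sc(C(c2ccc(F)cc2)c2ccc(F)cc2)nc1-c1ccnc(F)c1`, 0.48 nM
compound 3, `N#Cc1ccc(-c2nc(C(c3ccc(F)cc3)c3ccc(F)cc3)sc2CC(=O)O)cc1`, 150 nM

The read-out is an in vitro assay on HEK385-7 cells for displacement of a labelled ligand from prostaglandin D2 receptor 2 (Homo sapiens); on this read-out lower numbers stand for stronger inhibition and higher numbers for weaker inhibition. On the three numbers shown, compound 1 stands second highest: compound 3 is nearest with a 2.6-fold higher number from compound 1 to compound 3 (0.42 log units; beyond the scatter), while compound 2 is furthest with a 120-fold lower number from compound 1 to compound 2 (2.07 log units; beyond the scatter). The unmeasured compound 4, `O=C(O)Cc1sc(C(c2ccc(F)cc2)c2ccc(F)cc2)nc1-c1ccc(Cl)cc1`, differs from compound 1 in one place: 4-chlorophenyl in place of 3-cyano-4-fluorophenyl on an aromatic carbon. Among the measured compounds shown here, two measured steps bear on a change of the group at this position. The step from compound 1 to compound 3 was modest, and the step from compound 2 to compound 3, a 310-fold higher number from compound 2 to compound 3 (2.49 log units; beyond the scatter), was large, showing that this position can move the number strongly. For compound 4 neither a nitrile nor a ring nitrogen remains, so the cue from compound 2 does not transfer directly, and the closer precedent is the modest shift seen with compound 3. Compound 4 is therefore expected to sit near compound 1 or somewhat higher, a step of a 1.6-fold higher number from compound 1 to compound 4 (0.20 log units; within the scatter), with an estimate of 90 nM and a range from 15 nM to 500 nM.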

Compound 4, half-maximal inhibitory concentration: 9.7 nM
Estimate against measurement, compound 4: 9.3-fold (0.97 log units) above, and the stated range ends above it.
By their numbers in this assay, from the lowest: compound 2; then compound 4; then compound 1; then compound 3.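

Chloro in place of cyano on the phenyl ring gives a 15-fold lower number from compound 3 to compound 4 (1.19 log units; beyond the scatter) in this assay, and the 4-chlorophenyl group also gives a 5.9-fold lower number from compound 1 to compound 4 (0.77 log units; beyond the scatter), so a ring of carbon only, without a ring nitrogen, can still bring a clear gain at this position. The 2-fluoropyridin-4-yl group nevertheless keeps its lead, with a 20-fold higher number from compound 2 to compound 4 (1.31 log units; beyond the scatter), and compound 2 remains the lowest of the four. No measurement at hand explains these differences.

Left open is how an unsubstituted phenyl group would read here, or a methoxy or trifluoromethyl group in place of the chloro of compound 4. Also open, as far as these compounds go, is whether chloro in place of the fluoro of the 2-fluoropyridin-4-yl group would hold the low number of compound 2.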